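Hydroxy for methoxy on the pyrazole aryl group

The compounds below may be only part of what the source reports. "The series", "measured", "known", "first", "only" and "open" are said of these compounds alone.

Of the compounds shown here, two have been measured in a functional assay on MDA-MB-468 cells (Homo sapiens) for inhibition, read by sulforhodamine B assay, with a stated time of 48 h; on this read-out lower numbers stand for higher toxicity in this test and higher numbers for lower toxicity in this test. Compound 1 `Cc1cc(O)cc(-c2nn(CC#N)cc2-c2ccnc(-c3ccc(Oc4ccccc4)cc3)c2)c1` gives 8280 nM. Compound 2 `COc1cc(C)cc(-c2nn(CC#N)cc2-c2ccnc(-c3ccc(N(C)C)cc3)c2)c1` gives 7240 nM. The two values differ by a gap that lies within the usual scatter of this assay, so the numbers shown give no ranking of compound 2 against compound 1; both sit in the same low-micromolar region of the read-out.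

Compound 3 `Cc1cc(O)cc(-c2nn(CC#N)cc2-c2ccnc(-c3ccc(N(C)C)cc3)c2)c1` has not yet been measured in this assay . It differs from compound 2 in one place: hydrogen in place of methyl on an oxygen on an aromatic ring. For the measured compounds named here, no measured pair shows this exact change, so nothing measured fixes its size or direction. Compound 1 carries the hydroxy group on an otherwise different scaffold and reads close to compound 2, which offers no sign of a large shift. The change is therefore expected to produce no step beyond the scatter, a 1.0-fold lower number from compound 2 to compound 3 (0.01 log units; within the scatter). Compound 3 is estimated to reach 7000 nM in this assay , with a range from 3000 nM to 16000 nM.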

Compound 3, concentration lethal to 50% of the cells: 9940 nM
Compound 3: the middle estimate sits 1.4-fold (0.15 log units) below what was measured, and the stated range covers the measured number.
By their numbers in this assay, from the lowest: compounds 2, 1 and 3 (each within the scatter of the next).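

In this assay, hydrogen in place of methyl on an oxygen on an aromatic ring now has a measured size in this series: a 1.4-fold higher number from compound 2 to compound 3 (0.14 log units; within the scatter), so methoxy to hydroxy on this aryl group gives two values that cannot be told apart. The second single-place comparison, dimethylamino in place of phenoxy on an aromatic carbon, gives a 1.2-fold higher number from compound 1 to compound 3 (0.08 log units; within the scatter), so with the 3-hydroxy-5-methylphenyl group held constant, these two groups on the other side of the molecule are not separated by this read-out either. Nothing available bears on the reason for these small steps.

From the compounds shown here alone, each of the two changes rests on one pair, so it remains open whether methoxy to hydroxy would read the same with phenoxy in place of dimethylamino. Also open, going by these compounds, is whether an ethoxy group or a longer alkoxy chain on that oxygen, or an amine or a carboxylic acid in place of the hydroxy group, would give a step beyond the scatter in this assay.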